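The compounds below may be only part of what the source reports. "The series", "measured", "known", "first", "only" and "open" are said of these compounds alone.

Compound 1 `c1ccc(COc2ccccc2Nc2ncnc3cc4c(cc23)OCCOCCOCCO4)cc1` and compound 2 `FC(F)(F)c1ccc(COc2ccccc2Nc2ncnc3cc4c(cc23)OCCOCCOCCO4)cc1` share one core and differ only in one substituent on the benzyl ring. In a functional assay on DU-145 cells (Homo sapiens) for antiproliferative activity, read by MTT assay, with a stated time of 72 h (on this read-out lower numbers stand for stronger inhibition and higher numbers for weaker inhibition), compound 1 gives 13900 nM. For compound 2 this assay reports only a limit, > 100000 nM, so its true number is not known. The one measured step, an at least 7.1-fold higher number from compound 1 to compound 2 (0.85 log units; beyond the scatter), is therefore open at the upper end, as shown by the limit of > 100000 nM in this assay, at which 1 of the 2 values shown sits. Compound 3 `O=[N+]([O-])c1ccc(COc2ccccc2Nc2ncnc3cc4c(cc23)OCCOCCOCCO4)cc1` is the unmeasured partner; going from compound 2 to compound 3 the change is nitro in place of trifluoromethyl on an aromatic carbon. Among the measured compounds shown here, no measured step compares a nitro group with a trifluoromethyl group at this position, so the step from compound 2 to compound 3 has no direct precedent; the only guide is that both substituents replace a hydrogen whose compound 1 sat at the number given, and the trifluoromethyl analogue fell past the limit. On this footing compound 3 is expected to remain weak, with an estimated at least 1.6-fold lower number from compound 2 to compound 3 (0.22 log units; that floor lies within the scatter) that cannot be fixed in direction. The estimate for compound 3 is 60000 nM, with a range from 15000 nM to 200000 nM.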

Compound 3, half-maximal inhibitory concentration: > 100000 nM
Compound 3: a limit, no number (the forecaster's own chance of this, stated with the estimate: 40%); middle value at least 1.6-fold (0.22 log units) from the limit.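

Compound 3 gives > 100000 nM in this assay, which is a limit and not a number. Nitro in place of hydrogen on this aromatic carbon, para to a large group, gives an at least 7.1-fold higher number from compound 1 to compound 3 (0.85 log units; beyond the scatter), so among the compounds shown the weakening seen with trifluoromethyl is no longer tied to that one group. Nitro and trifluoromethyl cannot be ranked against each other, and the step from compound 2 to compound 3 cannot be read, because both values stand at the same limit: the limit of > 100000 nM in this assay, at which 2 of the 3 values shown sit.

From the compounds shown here alone, how far the true numbers of compound 2 and compound 3 lie beyond that limit stays open, and so does any difference between them. Compound 1 gives 13900 nM. Also open, going by these compounds, is whether an amine, a methoxy group or a carboxylic acid on this same carbon would stay near compound 1 or would fall past the limit as well.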